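Benzyl in Place of Phenyl on the Nitrone Nitrogen

The source may hold more compounds than are shown below. What is called first, only, known or untested is meant among the compounds shown, and "the series" means these compounds.

Measured compounds:
compound 1, `[O-]/[N+](=C\c1cn(-c2ccc(F)cc2)nn1)c1ccccc1`: 10200 nM
compound 2, `[O-]/[N+](=C\c1cn(-c2ccc(Cl)cc2)nn1)c1ccccc1`: 9700 nM
compound 3, `[O-]/[N+](=C\c1cn(CCC(F)(F)C(F)(F)C(F)(F)C(F)(F)C(F)(F)C(F)(F)C(F)(F)C(F)(F)F)nn1)c1ccccc1`: > 100000 nM

For the measured compounds named here, in a functional assay on COLO 205 cells (Homo sapiens) for inhibition, read by MTT assay, with a stated time of 24 h (on this read-out lower numbers stand for stronger inhibition and higher numbers for weaker inhibition), compound 1 gives 10200 nM, one of only two plain numbers recorded. The other belongs to compound 2, which gives 9700 nM; the step from one to the other is a 1.1-fold lower number from compound 1 to compound 2 (0.02 log units; within the scatter), so the two stand together. For compound 3 the assay reports only a limit, namely (the limit of > 100000 nM in this assay, at which 1 of the 3 values shown sits), and no number.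

Compound 4, `[O-]/[N+](=C\c1cn(-c2ccc(F)cc2)nn1)Cc1ccccc1`, differs from compound 1 in a single place: benzyl in place of phenyl on a double-bonded nitrogen. Going by the values given here, no measured step touches this group. Among the compounds with values here, the one measured step, from compound 1 to compound 2, changes a halogen on an aromatic carbon and stays within the scatter, so it offers no direction for the present change. With nothing measured bearing on it, no step beyond the scatter is expected in this assay, in either direction. The step from compound 1 to compound 4 is therefore estimated as a 1.2-fold higher number from compound 1 to compound 4 (0.07 log units; within the scatter). For compound 4 the estimate in this assay is 12000 nM, expected to fall between 4000 nM and 40000 nM.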

Compound 4, half-maximal inhibitory concentration: > 100000 nM
Compound 4: no number, only a limit; the forecaster's own chance of this, stated with the estimate: 15%; middle value at least 8.3-fold (0.92 log units) away from the limit.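

On the double-bonded nitrogen, benzyl in place of phenyl gives an at least 9.8-fold higher number from compound 1 to compound 4 (0.99 log units; beyond the scatter) in this assay, while the only earlier step, a 1.1-fold lower number from compound 1 to compound 2 (0.02 log units; within the scatter), left the number unmoved, so this nitrogen is the first place shown where a change registers beyond the scatter. In this assay compound 4 gives > 100000 nM, which is a limit and not a number, so only a lowest size of the step can be read. That limit is shared with one other compound shown: the limit of > 100000 nM in this assay, at which 2 of the 4 values shown sit.

Whether this shift belongs to benzyl itself or would follow any replacement of phenyl stays open, since a methyl group, a phenethyl chain or a methoxy-bearing phenyl ring on this nitrogen is not among the compounds shown. The compounds shown also leave open whether benzyl would act the same way with chloro in place of fluoro on the aromatic carbon.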